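The compounds below may be only part of what the source reports. "The series", "measured", "known", "first", "only" and "open" are said of these compounds alone.

In a functional assay on HepG2 cells (Homo sapiens) for cytotoxicity, read by MTT assay (on this read-out higher numbers stand for weaker inhibition and lower numbers for stronger inhibition), compound 2 `CC(=O)C(C)CCCCc1cc(O)c(C)c(=O)o1` gives > 200000 nM, which is a limit of the assay and not a number. Compound 1 `Cc1c(O)cc(CCCCC(C)C)oc1=O` gives > 200000 nM, also a limit. Compound 3 `CCC(C)CCCCc1cc(O)c(C)c(=O)o1` gives > 200000 nM, again a limit. Among the compounds with values here, compound 2 therefore stands with its two relatives, and the whole series so far is summed up by the limit of > 200000 nM in this assay, at which 3 of the 3 values shown sit.

Compound 4 `Cc1c(O)cc(CCCCC(C)[C@H](C)O)oc1=O` differs from compound 2 by one change in the side chain: 1-hydroxyethyl in place of acetyl on a saturated chain carbon bound to two saturated chain carbons.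

Within the data shown here, three measured steps bear on this change, all made at the same chain carbon or close to it along the chain. They are a step that the two limits leave unreadable from compound 1 to compound 2, then a step that the two limits leave unreadable from compound 2 to compound 3, and finally a step that the two limits leave unreadable from compound 1 to compound 3. None of them has a readable size, so they offer no sign that changing this part of the chain moves this assay in either direction.

With compound 2 as the starting point, the expectation is a step that the limit leaves unreadable from compound 2 to compound 4, with no change beyond the usual scatter. For compound 4 the estimated value is 220000 nM, with an expected range from 120000 nM to 400000 nM.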

Compound 4, half-maximal inhibitory concentration: > 200000 nM
Compound 4 was reported as a limit; the forecaster's own chance of this, stated with the estimate: 80%; the middle value does not contradict the limit.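

No new step can be read: in this assay, compound 4 is reported only as a limit, as are compound 1, compound 2 and compound 3, so the steps among them have no readable size. The compounds shown leave open whether any change in this side chain would give an actual number in this assay, as the series so far gives only one result: the limit of > 200000 nM in this assay, at which 4 of the 4 values shown sit.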